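The source may hold more compounds than are shown below. What is called first, only, known or untested is meant among the compounds shown, and "the series" means these compounds.

Measured compounds:
- compound 1, `COC(=O)c1cc(-c2cnc(C(=O)CCc3ccc(-c4ccccc4)cc3)o2)ccn1`: 1.5 nM
- compound 2, `O=C(O)c1cc(-c2cnc(C(=O)CCc3ccc(-c4ccccc4)cc3)o2)ccn1`: 50 nM
- compound 3, `N#Cc1cccc(-c2cnc(C(=O)CCc3ccc(COc4ccccc4)cc3)o2)n1`: 0.56 nM

In an assay for inhibition of Fatty-acid amide hydrolase 1 (Rattus norvegicus) (on this read-out lower numbers stand for stronger inhibition and higher numbers for weaker inhibition), compound 2 gives the highest number of the three, that is the weakest inhibition shown here. The nearest measured compound is compound 1, which differs from it only in having a methyl on the oxygen next to the carbonyl; the step of a 33-fold higher number from compound 1 to compound 2 (1.52 log units; beyond the scatter) is large and well beyond the scatter.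

The compound still to be measured is compound 4, `NC(=O)c1cccc(-c2cnc(C(=O)CCc3ccc(-c4ccccc4)cc3)o2)n1`. Compared with compound 2 the change is 6-carbamoylpyridin-2-yl in place of 2-carboxypyridin-4-yl on an aromatic carbon. The free acid of compound 2 is thus gone, and a carbamoyl group sits on a pyridine attached through a different ring carbon.

Among the measured compounds shown here, only one measured step bears directly on this change: the step of a 33-fold higher number from compound 1 to compound 2 (1.52 log units; beyond the scatter) shows that removing the acid character of that group, here by capping it as an ester, goes with a much lower number. Compound 3, with a nitrile on a pyridin-2-yl ring and a different tail, gives 0.56 nM, which shows that a neutral group on this kind of pyridine is compatible with strong inhibition. A large step downward in this assay is therefore expected, roughly of the size seen between compound 1 and compound 2.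

For compound 4 the estimate in this assay is 2 nM, with a likely range from 0.5 nM to 10 nM, meaning an expected step of a 25-fold lower number from compound 2 to compound 4 (1.40 log units; beyond the scatter).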

Compound 4, inhibition constant: 1.2 nM
Compound 4: middle estimate off by 1.7-fold (0.22 log units), on the high side; the measured number falls inside the stated range.
By their numbers in this assay, from the lowest: compound 3; then compounds 4 and 1 (each within the scatter of the next); then compound 2.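

In this assay, replacing 2-carboxypyridin-4-yl with 6-carbamoylpyridin-2-yl gives a 42-fold lower number from compound 2 to compound 4 (1.62 log units; beyond the scatter), so the weak inhibition of compound 2 is not a fixed feature of having a pyridine group at this place on the five-membered ring. The comparison with the ester gives a 1.3-fold lower number from compound 1 to compound 4 (0.10 log units; within the scatter), which means that compound 1 and compound 4 cannot be told apart in this read-out. Low numbers at this position are therefore not tied to the methyl ester of compound 1, since a carbamoyl group on a pyridine joined through a different ring carbon gives a value within the scatter of the ester.

The change from compound 2 to compound 4 alters the group on the pyridine and the pyridine's point of attachment together, so these compounds cannot show how much each contributes, and 2-carbamoylpyridin-4-yl or 6-carboxypyridin-2-yl on the same core would be needed to separate the two. Nothing measured here accounts for why the numbers shift as they do.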